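Swapping Amino for Dimethylamino on a Shared Core

The source may report more compounds than this note shows. Statements on the series, on what has been measured and on what is new or still open speak of the compounds shown alone.

Of the compounds shown here, three have been measured in an assay on CHO-K1 cells for binding affinity to 5-hydroxytryptamine receptor 1B (Homo sapiens); on this read-out lower numbers stand for stronger inhibition and higher numbers for weaker inhibition. Compound 1 `CN(C)[C@H]1C[C@H](c2c[nH]c3ccc(C(N)=O)cc32)C1` gives 44.7 nM, and compound 2 `CN(C)[C@H]1C[C@H](c2c[nH]c3ccc(CN4C(=O)CNC4=O)cc32)C1` gives 6310 nM. Compound 3 `N[C@H]1C[C@H](c2c[nH]c3ccc(Oc4ccccc4)cc32)C1` gives 9.55 nM, the lowest number of the three, with compound 1 coming nearest and compound 2 furthest away; both gaps lie beyond the scatter, so compound 3 is the strongest binder measured here.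

Compound 4 `CN(C)[C@H]1C[C@H](c2c[nH]c3ccc(Oc4ccccc4)cc32)C1` has not yet been measured. It differs from compound 3 in one place: dimethylamino in place of amino on a saturated ring carbon. Among the compounds with values here, none of the measured steps covers this exact change. Within the data shown here, the single step that has been measured, a 140-fold higher number from compound 1 to compound 2 (2.15 log units; beyond the scatter), concerns a different position on the aromatic part and is therefore not a direct guide. Among the measured compounds shown here, compound 1 and compound 3 differ in two places at once, so their values show only that a compound carrying dimethylamino can still bind well.

For the measured compounds named here, with no step bearing directly on this change, the expectation is a 1.3-fold higher number from compound 3 to compound 4 (0.10 log units; within the scatter), meaning compound 4 is estimated at 12 nM, within a range of 3 nM to 45 nM.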

Compound 4, half-maximal inhibitory concentration: 97.7 nM
Estimate against measurement, compound 4: 8.1-fold (0.91 log units) below; the whole stated range lies below it.
By their numbers in this assay, from the lowest: compound 3; then compound 1; then compound 4; then compound 2.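

In this assay, within the data shown here, dimethylamino in place of amino on this saturated ring carbon gives a 10-fold higher number from compound 3 to compound 4 (1.01 log units; beyond the scatter) and so shows that this carbon of the four-membered ring is sensitive to the change, which no earlier pair could show. With dimethylamino held fixed, the group on the aromatic carbon also moves the number in both directions: phenoxy in place of (2,5-dioxoimidazolidin-1-yl)methyl gives a 65-fold lower number from compound 2 to compound 4 (1.81 log units; beyond the scatter) while phenoxy in place of carbamoyl gives a 2.2-fold higher number from compound 1 to compound 4 (0.34 log units; beyond the scatter) and so places phenoxy between those two groups. Nothing measured here gives a reason for any of these steps.

On these data alone, whether the amino-to-dimethylamino swap has a similar size when carbamoyl replaces phenoxy remains open. So does where methylamino, the amine with a single methyl, would fall on this ring carbon.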